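Swapping the acetyl of a tolerated compound

The compounds below may be only part of what the source reports. "The series", "measured", "known", "first", "only" and "open" are said of these compounds alone.

Values in an ADME assay on MDBK cells (Bos taurus) for cytotoxicity, read by MTT assay, with a stated time of 96 h (a higher number here means that more compound is tolerated, a lower number that less compound is tolerated), for three compounds
Compound 1 `COc1ccc(-c2nc3cc(C(C)=O)ccc3[nH]2)c(OC)c1` gives 73000 nM
Compound 2 `COc1ccc(-c2nc3cc(C(C)=O)ccc3[nH]2)c(OC)c1OC` gives > 100000 nM (a limit)
Compound 3 `C/C(=N\O)c1ccc2[nH]c(-c3ccccc3)nc2c1` gives > 100000 nM (a limit)

At the limit of > 100000 nM in this assay, at which 2 of the 3 values shown sit, stand the other two, so only compound 1 has a full number. Compound 4 `COc1ccc(-c2nc3cc(/C(C)=N/O)ccc3[nH]2)c(OC)c1` differs from compound 1 by a group of 4 heavy atoms (2 carbon, 1 nitrogen, 1 oxygen; no ring) in place of a group of 3 heavy atoms (2 carbon, 1 oxygen; no ring), on an aromatic carbon and in nothing else, and the group that leaves is the acetyl. Within the data shown here, the only measured step, an at least 1.3-fold higher number from compound 1 to compound 2 (0.13 log units; that floor lies within the scatter) (methoxy in place of hydrogen), is a different change and does not test this swap. Compound 3 carries the entering group on a core without methoxy groups, and compound 3 gives > 100000 nM as a limit. That result gives no reason to expect a lower number. No step beyond the scatter is therefore expected in this assay and a result at the limit is quite possible. The expected step is a 1.1-fold higher number from compound 1 to compound 4 (0.04 log units; within the scatter) and is small. For compound 4 the estimated value is 80000 nM with an expected range of 30000 nM to 100000 nM as a rough guide.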

Compound 4, half-maximal cytotoxic concentration: > 100000 nM
Compound 4: no number, only a limit (the forecaster's own chance of this, stated with the estimate: 45%); middle value at least 1.2-fold (0.09 log units) from the limit.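

Putting the group of 4 heavy atoms in place of the acetyl gives an at least 1.3-fold higher number from compound 1 to compound 4 (0.13 log units; that floor lies within the scatter) in this assay, so no loss of tolerance appears when this aromatic carbon carries the new group on the core of compound 1. Compound 4 gives > 100000 nM, which is a limit. How much higher its true number lies cannot be read, and the assay leaves little room to separate these compounds: the limit of > 100000 nM in this assay, at which 3 of the 4 values shown sit.

The compounds shown leave open whether a different group on this aromatic carbon, such as an amine or a carboxylic acid in place of the acetyl, would bring the number down. They also leave open how the group of 4 heavy atoms would behave on the core of compound 2, with its additional methoxy.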